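Aminopyrimidine series: oxime removal from compound 2

The source may report more compounds than this note shows. Statements on the series, on what has been measured and on what is new or still open speak of the compounds shown alone.

Compound 1, `CCOc1ccc(Br)cc1-c1cc(Nc2cccc(C#N)c2)nc(N)n1`, gives 720 nM in an assay on Sf9 cells for inhibition of 1-acyl-sn-glycerol-3-phosphate acyltransferase beta (Homo sapiens); on this read-out lower numbers stand for stronger inhibition and higher numbers for weaker inhibition.
Compound 2, `CCOc1ccc(Br)cc1-c1cc(Nc2ccc(/C(C)=N\O)cc2)nc(N)n1`, gives 84 nM in this assay.

Compound 2 holds the lower of the two numbers; compound 1 sits higher by a gap beyond the scatter. Compound 3, `CCOc1ccc(Br)cc1-c1cc(Nc2ccccc2)nc(N)n1`, differs from compound 2 by a hydrogen atom in place of a group of 4 heavy atoms (2 carbon, 1 nitrogen, 1 oxygen; no ring), on an aromatic carbon. For the measured compounds named here, no measured pair shows this step, so its size is a guess. Going by the values given here, a loss beyond the scatter is expected, the step from compound 2 to compound 3 estimated at a 6.0-fold higher number from compound 2 to compound 3 (0.77 log units; beyond the scatter), since the removed group is the only feature setting compound 2 apart. Compound 3 is expected near 500 nM, within 150 nM to 2000 nM.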

Compound 3, half-maximal inhibitory concentration: 120 nM
Estimate against measurement, compound 3: 4.2-fold (0.62 log units) above, and the stated range ends above it.
By their numbers in this assay, from the lowest: compounds 2 and 3 (each within the scatter of the next); then compound 1.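

Removing the oxime group gives a 1.4-fold higher number from compound 2 to compound 3 (0.15 log units; within the scatter) in this assay, so the low number of compound 2 does not depend on that group. Hydrogen in place of cyano gives a 6.0-fold lower number from compound 1 to compound 3 (0.78 log units; beyond the scatter) and is the only step here beyond the scatter, so a substituent on this ring can cost far more than its removal does. Nothing available here bears on the reason for either step.

Still open, from the compounds shown here alone, is whether an amine, a carboxylic acid or a longer chain on this aromatic carbon would move the number beyond the scatter in either direction.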